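A few compounds are considered here, and "the series" means these few. Any claim that something is new, unique, unknown or untested is made for them only; others in the source may bear on it.

Measured so far:
Compound 1 `O=C(O)[C@H](CO)NC(=O)[C@H]1C[C@H](O)CN1` gives > 12 h
Compound 2 `O=C(O)[C@@H](CO)NC(=O)[C@H]1C[C@@H](O)CN1` gives > 12 h

In a physicochemical assay for metabolic stability, read by HPLC, with a stated time of 12 h, at pH 4.5 (a lower number here means that the compound disappears faster, a higher number that the compound lasts longer), compound 2 stands at > 12 h as a limit and not a number. Compound 1 stands at > 12 h as a limit too. Compound 3 `O=C(O)[C@@H](CO)NC(=O)[C@H]1C[C@H](O)CN1` is still unmeasured, and it differs from compound 2 as follows: the two compounds have the same atoms and bonds and differ only in configuration as drawn: 1 of 3 stereo elements differ; a stereocentre at a saturated ring carbon is drawn R in compound 2 and S in compound 3 and nothing leaves or enters.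

For the measured compounds named here, the one measured step that bears on this is a step that the two limits leave unreadable from compound 1 to compound 2 and it moves that ring stereocentre from S to R together with a stereocentre at a saturated chain carbon. All the data offer here is the limit of > 12 h in this assay, at which 2 of the 2 values shown sit, and no readable size. On that basis, the expected change is a step that the limit leaves unreadable from compound 2 to compound 3 in this assay and nothing beyond the scatter, in either direction, is expected. Compound 3 is expected at 20 h with an estimated range from 10 h to 40 h and most likely as another limit.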

Compound 3, half-life: > 12 h
Compound 3: a limit, no number (the forecaster's own chance of this, stated with the estimate: 90%); the middle value does not contradict the limit.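

In this assay compound 3 gives > 12 h, which is a limit and not a number. For the compounds shown here, compound 1 and compound 2 also stand at limits, so no step among compound 1, compound 2 and compound 3 can be read. As far as these compounds go, how long each compound lasts, and whether either stereocentre changes its half-life, remains open.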